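Shortening the fatty tail of compound 1

The source may report more compounds than this note shows. Statements on the series, on what has been measured and on what is new or still open speak of the compounds shown alone.

Compound 1, `CCCCCCCCCCCC(=O)NCC(=O)N[C@@H]1[C@@H](O)[C@H](O)[C@@H](Nc2ncnc3[nH]cnc23)O[C@H]1C`, carries a long fatty tail on its amide and a methyl on the ring. In a functional assay on L1210 cells (Mus musculus) for inhibition, with a stated time of 3 h (on this read-out lower numbers stand for an effect already at smaller amounts and higher numbers for an effect only at larger amounts of compound), compound 1 gives 18 uM, the highest number of the three measured. Compound 3, `CCCCCCCCCCCC(=O)NCC(=O)N[C@@H]1[C@@H](O)[C@H](O)[C@@H](Nc2ncnc3[nH]cnc23)O[C@H]1CO`, gives 5.5 uM, and the step of a 3.3-fold lower number from compound 1 to compound 3 (0.51 log units; beyond the scatter) shows what the hydroxy adds. Compound 2, `CC(C)CCCCCCCCCCCCC(=O)NCC(=O)N[C@@H]1[C@@H](O)[C@H](O)[C@@H](Nc2ncnc3[nH]cnc23)O[C@H]1CO`, gives 0.69 uM, and the step of an 8.0-fold higher number from compound 2 to compound 3 (0.90 log units; beyond the scatter) shows that trimming the far end of the tail moves the number upward.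

Compound 4, `CCCCCC(=O)NCC(=O)N[C@@H]1[C@@H](O)[C@H](O)[C@@H](Nc2ncnc3[nH]cnc23)O[C@H]1C`, differs from compound 1 by hydrogen in place of hexyl on a saturated chain carbon, five bonds along the chain from a carbonyl carbon. This removes a large part of the tail, much more than the isobutyl lost in the step from compound 2 to compound 3. Among the compounds with values here, only that step bears on the change, and it points to a weaker effect when the tail is shortened. Compound 4 is therefore expected to give a markedly higher number, estimated at 120 uM with a likely range from 35 uM to 400 uM, a step of a 6.7-fold higher number from compound 1 to compound 4 (0.82 log units; beyond the scatter).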

Compound 4, concentration for half-maximal effect: > 1000 uM
Compound 4 was reported as a limit; the forecaster's own chance of this, stated with the estimate: 30%; middle value at least 8.3-fold (0.92 log units) away from the limit.
By their numbers in this assay, from the lowest: compound 2; then compound 3; then compound 1. At a limit, above all of these: compound 4.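

The value for compound 4 is a limit in this assay: the limit of > 1000 uM in this assay, at which 1 of the 4 values shown sits.

Hydrogen in place of hexyl, five bonds along the chain from a carbonyl carbon, gives a large step, an at least 55-fold higher number from compound 1 to compound 4 (1.74 log units; beyond the scatter). The earlier change in the tail, isobutyl to hydrogen, gave a modest step, an 8.0-fold higher number from compound 2 to compound 3 (0.90 log units; beyond the scatter), and left a measured number, so it did not show that a change in this chain could take the effect out of measurable range altogether.

The compounds shown leave open where along the chain between hexyl and hydrogen the effect is lost, since no tail of intermediate length appears among them. They also leave open whether hydroxy in place of hydrogen on the ring-bound carbon of compound 4 would bring back a measurable number, and whether an amine or a carboxylic acid in place of hexyl would do so.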